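Side-chain change on the 4-chlorophenyl amine series

The compounds below may be only part of what the source reports. "The series", "measured", "known", "first", "only" and "open" are said of these compounds alone.

Compound 1 `C[C@@H](C(=O)NC1CCCCC1)[C@H]1CC[C@@H](c2ccnc3ccc(F)cc32)CC1` gives < 1% (a limit)
Compound 2 `C[C@@H](CNc1ccc(Cl)cc1)[C@H]1CC[C@@H](c2ccnc3ccc(F)cc32)CC1` gives 80%
Compound 3 `C[C@@H](CNC(=O)c1ccc(Cl)cc1)[C@H]1CC[C@@H](c2ccnc3ccc(F)cc32)CC1` is not yet measured

Among the measured compounds shown here, in an ADME assay on microsomes from liver (Mus musculus) for metabolic stability, with a stated time of 10 min, tested at 0.5 uM (a higher number here means that more of the compound is left, a lower number that less of the compound is left), compound 2 stands at 80% as the only true number so far. Compound 1 gives < 1% as a limit of the assay. The change to compound 3 is (4-chlorophenyl)carbonyl in place of 4-chlorophenyl on an amine nitrogen. For the measured compounds named here, the one measured step, ((4-chlorophenyl)amino)methyl in place of cyclohexylcarbamoyl, is large (a number at least 79 percentage points higher from compound 1 to compound 2 (beyond the scatter)) but bears only in part: compound 3 keeps the 4-chlorophenyl of compound 2 and gains a carbonyl, which compound 1 also carries. A moderate fall in this assay is therefore expected (a number 20 percentage points lower from compound 2 to compound 3 (beyond the scatter)). Compound 3 is estimated at 60% (expected range 25% to 90%).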

Compound 3, percent of the compound remaining: 32%
For compound 3 the middle estimate is 28 percentage points above the measured one; low and high end bracket the measured number.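

Placing (4-chlorophenyl)carbonyl in place of 4-chlorophenyl on an amine nitrogen gives a number 48 percentage points lower from compound 2 to compound 3 (beyond the scatter) in this assay and shows that this nitrogen is sensitive to what it carries. The 4-chlorophenyl is present in both compounds, so the large step comes with the added carbonyl alone, which the earlier pair, differing in the whole side chain, could not separate. No measurement shown gives a cause for this fall.

Open, as far as these compounds go, is how a sulfonyl or a methylene in place of this carbonyl would read in this assay. Also open, from the compounds shown here alone, is how a plain phenyl in place of the 4-chlorophenyl would read on either nitrogen.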